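The source may hold more compounds than are shown below. What is called first, only, known or untested is meant among the compounds shown, and "the series" means these compounds.

In an ADME assay on MDCK cells (Canis lupus familiaris) for cytotoxicity, read by microscopy, with a stated time of 48 h (a lower number here means that less compound is tolerated, a higher number that more compound is tolerated), compound 1 `CSc1ccc(CN[C@@H]2C[C@H]3C[C@@H]([C@H]2C)C3(C)C)s1` gives 25000 nM. Compound 2 `C[C@H]1[C@H](NCc2cc(C3CC3)cs2)C[C@H]2C[C@@H]1C2(C)C` gives 25000 nM in this assay, which stands level with compound 1 at the digits shown, a gap that lies within the scatter of repeated measurements. Among the compounds with values here, compound 3 `C[C@H]1[C@H](NCc2cncs2)C[C@H]2C[C@@H]1C2(C)C` returns only a limit in this assay, > 100000 nM, and no number; it is the one value of the three that sits at the limit of > 100000 nM in this assay, at which 1 of the 3 values shown sits. Compound 4 `C=Cc1csc(CN[C@@H]2C[C@H]3C[C@@H]([C@H]2C)C3(C)C)c1` has not yet been measured in this assay. It differs from compound 2 in one place: vinyl in place of cyclopropyl on an aromatic carbon. Within the data shown here, no step between measured compounds speaks to this change. The values of compound 1 and compound 2 sit at the same level, and nothing among the three measured compounds points to vinyl in place of cyclopropyl moving the tolerated concentration in either direction. In this assay compound 4 is therefore expected to give 25000 nM, with a range from 12500 nM to 50000 nM. The step of no change at the digits printed from compound 2 to compound 4 (within the scatter) that this estimate implies is expected to be none beyond the scatter.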

Compound 4, minimum cytotoxic concentration: 6250 nM
Compound 4: the middle estimate sits 4.0-fold (0.60 log units) above what was measured, outside the stated range (below it).
By their numbers in this assay, from the lowest: compound 4; then compounds 1 and 2 (each within the scatter of the next). At a limit, above all of these: compound 3.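

In this assay, vinyl in place of cyclopropyl on an aromatic carbon, two ring bonds from the ring sulfur, gives a 4.0-fold lower number from compound 2 to compound 4 (0.60 log units; beyond the scatter). This is the first step shown between compounds that differ in one place, and it shows that the number in this assay is not indifferent to the group at this position. The change removes a three-membered ring of carbon and brings in a double bond outside aromatic rings, but nothing measured here bears on why the number moves.

A single step does not separate the loss of the ring from the arrival of the double bond; an ethyl group at this position would stand between the two. Going by these compounds, whether an amine or a carboxylic acid at this position would shift the number in the same direction also stays open.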